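The source may report more compounds than this note shows. Statements on the series, on what has been measured and on what is new or still open speak of the compounds shown alone.

Compound 3 `COc1ccccc1N1CCN(CCCCNC(=O)c2ccc(N)cc2)CC1` carries a 4-aminophenyl on a carbonyl carbon of its amide. In an assay on frontal cortex for binding affinity to Adrenergic receptor alpha-1 (Rattus norvegicus), read by radioligand binding (on this read-out higher numbers stand for weaker inhibition and lower numbers for stronger inhibition), compound 3 gives 23 nM. Compound 1 `O=C1c2ccccc2C(=O)N1CCCCN1CCN(c2cccc3ccccc23)CC1` gives 22 nM in this assay, a number within the scatter of compound 3, so the two cannot be told apart. Compound 2 `CC(=O)Nc1ccc(N2CCN(CCCCN3C(=O)c4ccccc4C3=O)CC2)cc1` gives only a limit in this assay, namely < 1000 nM. Among the compounds with values here, the one measured step, a step that the limit leaves unreadable from compound 1 to compound 2, stays unreadable because of the limit of < 1000 nM in this assay, at which 1 of the 3 values shown sits. Compound 4 `COc1ccccc1N1CCN(CCCCNC(=O)C(C)(C)C)CC1` differs from compound 3 by tert-butyl in place of 4-aminophenyl on a carbonyl carbon. Within the data shown here, no measured step touches this end of the molecule, so the expectation rests on the change alone, and binding is expected to weaken somewhat, giving an expected step of a 4.3-fold higher number from compound 3 to compound 4 (0.64 log units; beyond the scatter). Compound 4 is estimated at 100 nM, between 25 nM and 400 nM.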

Compound 4, inhibition constant: 74 nM
Beside the measured number, compound 4's estimate is 1.4-fold (0.13 log units) above it; the measured number falls inside the stated range.
By their numbers in this assay, from the lowest: compounds 1 and 3 (each within the scatter of the next); then compound 4.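

In this assay, within the data shown here, this is the first readable change at this end of the molecule: a 3.2-fold higher number from compound 3 to compound 4 (0.51 log units; beyond the scatter) is the cost of putting tert-butyl in place of 4-aminophenyl on the carbonyl carbon. Binding weakens modestly but is not lost, so an aromatic ring at this place is not required for a clear reading. No measurement shown explains this step. Still open, on these data alone, is whether the ring or its amine counts for more; a plain phenyl or a cyclohexyl on this carbonyl carbon would separate the two.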